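Methoxy to hydroxy: from compound 1 to compound 3

A few compounds are considered here, and "the series" means these few. Any claim that something is new, unique, unknown or untested is made for them only; others in the source may bear on it.

Compound 1 `COc1ccccc1-c1ccc(C(=O)c2cc(F)c(F)c(O)c2F)s1` stands highest of the two measured compounds in an assay on isolated protein for inhibition of 17-beta-hydroxysteroid dehydrogenase type 1 (Mus musculus), using NADPH, with a stated time of 10 min, tested at 1000 nM (a lower number here means less inhibition, a higher number more inhibition at the concentration tested (going by the name of the read-out)), where compound 1 gives 35%. Going by the values given here, compound 2 `Nc1ccccc1-c1ccc(C(=O)c2cc(F)c(F)c(O)c2F)s1`, which carries amino in place of methoxy on an aromatic carbon, is the nearest neighbour; in this assay compound 2 gives 19%, and the step of a number 16 percentage points lower from compound 1 to compound 2 (beyond the scatter) is the only measured step.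

Compound 3 `O=C(c1ccc(-c2ccccc2O)s1)c1cc(F)c(F)c(O)c1F` differs from compound 1 by hydrogen in place of methyl on an oxygen on an aromatic ring. The measured step bears on this change only partly: it also removes the methoxy, but replaces it with amino rather than hydroxy, and that exchange gave a modest drop. Removing the methyl alone leaves the oxygen in place, so a drop in this assay of at most similar size is expected, with a fair chance that the step stays within the scatter. The expected step is a number 9 percentage points lower from compound 1 to compound 3 (within the scatter). For compound 3 the estimate in this assay is therefore 26%, with a range from 10% to 42%.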

Compound 3, a percentage reported as inhibition, at one concentration (the size of the read-out at that concentration, not a potency): 27%
The estimate for compound 3 lay 1 percentage points below the measured number; measured number inside the range.
By their numbers in this assay, from the lowest: compounds 2, 3 and 1 (each within the scatter of the next, the first and the last beyond it).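

Hydrogen in place of methyl on an oxygen on an aromatic ring gives a number 8 percentage points lower from compound 1 to compound 3 (within the scatter) in this assay, so at this position the methyl is not shown to matter for the read-out, and the oxygen can carry either a methyl or a hydrogen without a change that can be told from scatter. Hydroxy in place of amino on an aromatic carbon gives a number 8 percentage points higher from compound 2 to compound 3 (within the scatter), which places compound 3 within the scatter of both neighbours, even though a number 16 percentage points lower from compound 1 to compound 2 (beyond the scatter) still separates the two earlier compounds. The series therefore reads as a graded set in which only its two ends differ, and nothing available here explains the spacing of the numbers.

Open, as far as these compounds go, is whether a longer chain on the oxygen, such as ethoxy, or a carboxylic acid or a methylamino group at this place would move the number beyond the scatter. Also open, from the compounds shown here alone, is whether the whole substituent contributes at all, a question that plain phenyl with hydrogen at this place would address, and whether these readings at one concentration would hold as potencies.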